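Swapping a furan for a thiophene on the dihydropyrimidinone core

The compounds below may be only part of what the source reports. "The series", "measured", "known", "first", "only" and "open" are said of these compounds alone.

Measured compounds:
compound 1 `CCCOC(=O)C1=C(C)NC(=O)NC1c1cccs1` gives 32%
compound 2 `CC1=C(C(=O)CC(C)C)C(c2ccoc2)NC(=O)N1` gives 18%

Both values come from an assay on membranes from HeLa cells for displacement of a labelled ligand from adenosine receptor A3 (Homo sapiens), read by scintillation counting, with a stated time of 180 min, tested at 1 uM; on this read-out higher numbers stand for more inhibition at the one concentration tested (going by the name of the read-out) and lower numbers for less inhibition. Of the two numbers, compound 2 stands at the lowest; its nearest neighbour is compound 1, whose number lies higher by an amount beyond the usual scatter. The two compounds differ in more than one place, so their values can only be read side by side, not as a single step.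

Compound 3 `CC1=C(C(=O)CC(C)C)C(c2cccs2)NC(=O)N1` has not yet been measured. It differs from compound 2 in one place: thiophen-2-yl in place of furan-3-yl on a saturated ring carbon. The group that enters is the same five-membered ring that compound 1 carries on the corresponding saturated ring carbon of the shared core, while the isobutylcarbonyl group of compound 2 is kept.

For the measured compounds named here, no measured pair isolates this one change, so the expected step rests on the two values shown. Because compound 1 with its thiophen-2-yl reads 32%, a modest rise in this assay from compound 2 to compound 3 is expected, of about a number 9 percentage points higher from compound 2 to compound 3 (within the scatter). Compound 3 is estimated at 27%, with a likely range from 12% to 42%.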

Compound 3, a percentage reported as inhibition, at one concentration (the size of the read-out at that concentration, not a potency): 18%
For compound 3 the middle estimate is 9 percentage points above the measured one; the range from low to high includes it.
By their numbers in this assay, from the lowest: compounds 2 and 3 (each within the scatter of the next); then compound 1.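

In this assay, thiophen-2-yl in place of furan-3-yl on the saturated ring carbon gives no change at the digits printed from compound 2 to compound 3 (within the scatter), so with the isobutylcarbonyl group kept, this read-out does not separate these two five-membered rings. The comparison with compound 1 now has thiophen-2-yl on both sides and differs in one place only: isobutyl in place of propoxy on a carbonyl carbon gives a number 14 percentage points lower from compound 1 to compound 3 (beyond the scatter), a step beyond the scatter that compound 2 and compound 1, which differ in more than one place, could not isolate. Nothing at hand accounts for the size of either step.

The step from furan-3-yl to thiophen-2-yl changes both the hetero atom and the point of attachment, so furan-2-yl or thiophen-3-yl would be needed to follow each change alone, and a phenyl ring would show what happens with no hetero atom at this position. On the carbonyl carbon, only propoxy and isobutyl appear here, leaving open how an ethoxy group, a longer alkoxy chain or an amine would read alongside them.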